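Removing one chloro from a dithiocarbamate triazole

The compounds below may be only part of what the source reports. "The series", "measured", "known", "first", "only" and "open" are said of these compounds alone.

Measured so far:
- compound 1 `Cc1cc(=O)oc2cc(OCCn3cc(CSC(=S)N4CCN(C(=O)OC(C)(C)C)CC4)nn3)ccc12`: 76900 nM
- compound 2 `S=C(SCc1cn(Cc2ccc(Cl)c(Cl)c2)nn1)N1CCNCC1`: "not determined" (no result reported)
- compound 3 `O=C(OCc1ccccc1)N1CCN(C(=S)SCc2cn(Cc3ccc(Cl)c(Cl)c3)nn2)CC1`: 7140 nM

Compound 2 carries a free piperazine nitrogen and was not given a number. In a functional assay on MGC-803 cells (Homo sapiens) for inhibition, read by MTT assay, with a stated time of 72 h (a lower number here means a stronger inhibitor, a higher number a weaker inhibitor), compound 1 gives 76900 nM, while compound 3 gives 7140 nM, the lowest of the two numbers and beyond the usual scatter from compound 1. Compound 3 is thus the stronger inhibitor of the pair with a number.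

Compound 4 `O=C(OCc1ccccc1)N1CCN(C(=S)SCc2cn(Cc3ccc(Cl)cc3)nn2)CC1` is the next step. It differs from compound 3 only in one place: hydrogen in place of chloro on an aromatic carbon

Within the data shown here, no pair of measured compounds shows what removing a single chloro does in this assay, so the direction of this step is uncertain. A modest weakening is expected, possibly within the scatter, since compound 3 shows 7140 nM and the benzyl carbamate and the dithiocarbamate linker are unchanged. The expected step is a 1.7-fold higher number from compound 3 to compound 4 (0.23 log units; within the scatter). Compound 4 is estimated at 12000 nM, within a range from 4000 nM to 36000 nM.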

Compound 4, half-maximal inhibitory concentration: 31300 nM
The estimate for compound 4 lay 2.6-fold (0.42 log units) below the measured number; the range from low to high includes it.
By their numbers in this assay, from the lowest: compound 3; then compound 4; then compound 1.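

In this assay, among these compounds, trimming the 3,4-dichlorophenyl ring to a 4-chlorophenyl ring gives a 4.4-fold higher number from compound 3 to compound 4 (0.64 log units; beyond the scatter), the first change in this set that can be read at a single place. The chloro that leaves sits ortho to a chloro group and meta to a large group, and with the rest of the structure unchanged, losing this one heavy atom is enough to move the number beyond the usual scatter, so the second chloro counts for activity in these cells. Nothing measured here tells why this chloro matters.

From the compounds shown here alone, whether a fluoro, a methyl or a methoxy group on that same carbon would keep the lower number of compound 3 remains open. Also open, going by these compounds, is what a plain benzyl group, with the remaining chloro replaced by hydrogen, would give.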